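Replacing Hydroxymethyl with Isobutylamino

A few compounds are considered here, and "the series" means these few. Any claim that something is new, unique, unknown or untested is made for them only; others in the source may bear on it.

For the measured compounds named here, in a physicochemical assay for acid dissociation, compound 1 `NS(=O)(=O)c1ccc(S(=O)(=O)CCCO)s1` gives 8.32 and compound 2 `NS(=O)(=O)c1ccc(S(=O)(=O)CCCCO)s1` gives 8.67, so compound 2 holds the higher of the two numbers so far. Compound 3 `CC(C)CNCCCS(=O)(=O)c1ccc(S(N)(=O)=O)s1` is not yet measured. It carries isobutylamino in place of hydroxymethyl on a saturated chain carbon, three bonds along the chain from a sulfonyl sulfur.

Going by the values given here, only one measured step bears on this change. At the same place, hydroxymethyl in place of hydroxy gave a number 0.35 log units higher from compound 1 to compound 2 (beyond the scatter), a modest change. Among the compounds with values here, no measured compound carries isobutylamino, so that step is only a rough guide to size and gives no direction. In this assay, the expected result is a number 0.03 log units higher from compound 2 to compound 3 (within the scatter), which would not lie beyond the scatter. Compound 3 is estimated at 8.7, with an expected range from 8.1 to 9.4.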

Compound 3, acid dissociation constant: 9.3
Compound 3: middle estimate off by 0.60 log units, on the low side; the range from low to high includes it.
By their numbers in this assay, from the lowest: compound 1; then compound 2; then compound 3.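

In this assay putting isobutylamino in place of hydroxymethyl gives a number 0.63 log units higher from compound 2 to compound 3 (beyond the scatter) and putting it in place of hydroxy gives a number 0.98 log units higher from compound 1 to compound 3 (beyond the scatter) at this same place on the chain. The earlier pair compared only two chains ending in hydroxy, whereas these steps show that a group with nitrogen and no oxygen can also raise the number here, leaving compound 3 highest of the three. The data shown offer no measured explanation for this rise.

The compounds shown cannot separate the part played by the nitrogen from that of the isobutyl carbons, since both enter together. A plain amino group or a carboxylic acid at this place would be needed to tell how far the number follows the kind of group.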